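The source may hold more compounds than are shown below. What is called first, only, known or untested is meant among the compounds shown, and "the series" means these compounds.

Working notes on a small set of closely related compounds, all read in one cytotoxicity assay.

Compound 1 `COc1cccc2[nH]cc(C3(c4c[nH]c5cccc(OC)c45)C(=O)Nc4ccccc43)c12` and compound 3 `COc1cccc2[nH]cc(C3(c4c[nH]c5cccc(OC)c45)C(=O)Nc4ccc(F)cc43)c12` share one core. In a functional assay on DU-145 cells (Homo sapiens) for cytotoxicity, read by MTT assay, with a stated time of 48 h (a lower number here means a stronger inhibitor, a higher number a weaker inhibitor), compound 1 gives 5000 nM, and compound 3 gives 9400 nM. The difference between them, (fluoro in place of hydrogen on an aromatic carbon), produced a 1.9-fold higher number from compound 1 to compound 3 (0.27 log units; within the scatter).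

Compound 2 `O=C1Nc2ccccc2C1(c1c[nH]c2ccc(Cl)cc12)c1c[nH]c2ccc(Cl)cc12` is built on a different core; the difference between the two cores is not broken down here. In this assay compound 2 gives 8100 nM, which sits within the scatter of both compound 3 and compound 1.

Compound 4 `O=C1Nc2ccc(F)cc2C1(c1c[nH]c2ccc(Cl)cc12)c1c[nH]c2ccc(Cl)cc12` has not yet been measured. It differs from compound 2 by fluoro in place of hydrogen on an aromatic carbon, the same change at the same place as that between compound 1 and compound 3. Among the measured compounds shown here, the step from compound 2 to compound 4 is expected to be a 1.5-fold higher number from compound 2 to compound 4 (0.17 log units; within the scatter), set beside a 1.9-fold higher number from compound 1 to compound 3 (0.27 log units; within the scatter); this rests on that single measured pair, and no second example is available in the set. For compound 4 the value expected in this assay is 12000 nM, with a range from 5000 nM to 30000 nM.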

Compound 4, half-maximal inhibitory concentration: 19600 nM
The estimate for compound 4 lay 1.6-fold (0.21 log units) below the measured number, and the stated range covers the measured number.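

In this assay, fluoro in place of hydrogen on an aromatic carbon gives a 2.4-fold higher number from compound 2 to compound 4 (0.38 log units; beyond the scatter), a modest step, on the core of compound 2. Set beside the step on the core of compound 1, this shows that the change carries from one core to the other without a size difference that can be told from the scatter: the same change on two cores in this assay, a 1.9-fold higher number (0.27 log units; within the scatter) from compound 1 to compound 3 and a 2.4-fold higher number (0.38 log units; beyond the scatter) from compound 2 to compound 4, 1.3-fold (0.11 log units) apart, within the scatter of two such steps. Among the compounds shown here, it does not show a firm rise on both cores, since only the step on the core of compound 2 passes beyond the scatter, and two pairs in a single assay cannot establish a general rule for the series or explain the step.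

The compounds shown leave open how a group other than fluoro, such as a nitrile, an amine or a carboxylic acid, would read at this same place on either core. They also leave open whether the step seen here would recur on a third core.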